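Moving a nitrile: 2-cyanophenyl to 4-cyanophenyl

This account rests on a few compounds, and the source may have more. Where it says the series, first, only, none or still open, it means among the compounds named here.

In an ADME assay on MT4 cells (Homo sapiens) for cytotoxicity, read by MTT assay, with a stated time of 5 days (on this read-out lower numbers stand for higher toxicity in this test and higher numbers for lower toxicity in this test), the measured compounds are:
compound 1 `COc1cc2nc([S+]([O-])CC(=O)Nc3cccc(C(F)(F)F)c3)nc(Nc3c(Cl)cc(/C=C/C#N)cc3Cl)c2cc1OC` with 21800 nM
compound 2 `COc1cc2nc([S+]([O-])CC(=O)Nc3ccccc3C#N)nc(Nc3c(Cl)cc(/C=C/C#N)cc3Cl)c2cc1OC` with > 206000 nM (a limit)

Compound 2 gives > 206000 nM in this assay and this is a limit of the assay, not a number. It therefore stands at the limit of > 206000 nM in this assay, at which 1 of the 2 values shown sits, and has no exact value.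

Compound 3 `COc1cc2nc([S+]([O-])CC(=O)Nc3ccc(C#N)cc3)nc(Nc3c(Cl)cc(/C=C/C#N)cc3Cl)c2cc1OC` keeps the shared core and differs from compound 2 in one place, with 4-cyanophenyl in place of 2-cyanophenyl on an amide-type nitrogen. The two have the same atoms, joined differently.

Going by the values given here, one measured step bears on this change. Putting 2-cyanophenyl in place of 3-(trifluoromethyl)phenyl on that nitrogen gave an at least 9.4-fold higher number from compound 1 to compound 2 (0.97 log units; beyond the scatter) and so lay beyond the scatter. That step shows that the group on this nitrogen can move the number, but there the whole group was exchanged, whereas here the nitrile is kept. Among the compounds with values here, compound 1 gives 21800 nM and so marks the only exact number available. A modest move towards lower numbers is therefore expected, and the assay may again report only a limit. The expected change is an at least 2.9-fold lower number from compound 2 to compound 3 (0.46 log units; beyond the scatter) on this estimate. Compound 3 is expected at 70000 nM with a range from 18000 nM to 206000 nM on this estimate.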

Compound 3, half-maximal cytotoxic concentration: >= 188000 nM
Compound 3: no number, only a limit (the forecaster's own chance of this, stated with the estimate: 40%); middle value at least 2.6-fold (0.42 log units) away from the limit.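

In this assay compound 3 gives >= 188000 nM, and this is a limit of the assay, not a number. Putting 4-cyanophenyl in place of 3-(trifluoromethyl)phenyl on the amide-type nitrogen gives an at least 8.6-fold higher number from compound 1 to compound 3 (0.93 log units; beyond the scatter), so the higher number seen earlier with 2-cyanophenyl is not confined to that one placing of the nitrile. The step between the two nitrile-bearing groups cannot be read, and compound 2 also stands only at a limit of the assay: the limit of > 206000 nM in this assay, at which 1 of the 3 values shown sits.

From the compounds shown here alone, neither compound 2 nor compound 3 has an exact value, so it stays open whether 2-cyanophenyl and 4-cyanophenyl differ at all in this assay. Also open, going by these compounds, is whether the higher numbers go with the nitrile itself or would also appear with other groups on the phenyl ring at this nitrogen, such as a carboxylic acid or an amine.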